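Adding a 4-Methoxyphenyl Group to Compound 3

The source may hold more compounds than are shown below. What is called first, only, known or untested is meant among the compounds shown, and "the series" means these compounds.

Compound 1 `Cc1c(F)cc(C(=O)NC2CCCCCC2)c(=O)n1Cc1ccc(F)cc1` — > 10000 nM
Compound 2 `Cc1c(Cl)cc(C(=O)NC2CCCCCC2)c(=O)n1Cc1ccc(F)cc1` — > 10000 nM
Compound 3 `Cc1ccc(C(=O)NC2CCCCCC2)c(OCc2ccc(F)cc2)n1` — > 10000 nM

In an assay on HEK293 cells for inhibition of Monoacylglycerol lipase ABHD6 (Homo sapiens), read by scintillation counting, with stated times of 30 min and 5 min (a lower number here means a stronger inhibitor, a higher number a weaker inhibitor), compound 1 gives > 10000 nM, which is a limit of the assay and not a number. Compound 2 likewise gives only the limit > 10000 nM. Compound 3 also stands at the limit > 10000 nM. For the measured compounds named here, all three values sit at the limit of > 10000 nM in this assay, at which 3 of the 3 values shown sit, so no compound here has a measured number. The step that the two limits leave unreadable from compound 1 to compound 2 therefore cannot be read. Compound 4 `COc1ccc(-c2cc(C(=O)NC3CCCCCC3)c(OCc3ccc(F)cc3)nc2C)cc1` differs from compound 3 by 4-methoxyphenyl in place of hydrogen on an aromatic carbon. No measured step involves a change of this kind, and the only shown step is unreadable, so the direction and size of the change in this assay remain open. A step of an at least 2.5-fold lower number from compound 3 to compound 4 (0.39 log units; beyond the scatter) is expected only as a tentative guess, so compound 4 is estimated at 4000 nM, ranging from 300 nM to 20000 nM.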

Compound 4, half-maximal inhibitory concentration: 530 nM
Compound 4: the middle estimate sits 7.5-fold (0.88 log units) above what was measured; low and high end bracket the measured number.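

In this assay, 4-methoxyphenyl on this aromatic carbon, ortho to a methyl group and para to a (4-fluorobenzyl)oxy group, produces an at least 18-fold lower number from compound 3 to compound 4 (1.27 log units; beyond the scatter). For the compounds shown here, this is the first readable step, and it shows that this position, which carries only hydrogen in compound 3, can take a large aromatic group with a clear gain. The figure for compound 3 is a limit and not a number.

The compounds shown do not tell whether the methoxy group matters or the ring alone suffices. A plain phenyl or a 4-chlorophenyl group at this position would separate the two.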